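From 3-chlorophenyl to 2-bromophenyl on the ring amine

A few compounds are considered here, and "the series" means these few. Any claim that something is new, unique, unknown or untested is made for them only; others in the source may bear on it.

Compound 1 `CCCn1c(=O)[nH]c2nc(-c3ccc(S(=O)(=O)N4CCN(C)CC4)cc3)[nH]c2c1=O` is the starting point of this short series. In an assay on CHO cells for displacement of a labelled ligand from adenosine receptor A1 (Homo sapiens), read by scintillation counting, with a stated time of 90 min, in the presence of a further agent that is not named here (a higher number here means a weaker inhibitor, a lower number a stronger inhibitor), compound 1 gives 334 nM. Compound 2 `CCCn1c(=O)[nH]c2nc(-c3ccc(S(=O)(=O)N4CCN(c5cccc(Cl)c5)CC4)cc3)[nH]c2c1=O` carries a 3-chlorophenyl group instead of the methyl on the amine nitrogen in the ring. In this assay compound 2 reaches only the ceiling of the test, > 1000 nM, so for it a limit rather than a number is known. The step of an at least 2.9-fold higher number from compound 1 to compound 2 (0.47 log units; beyond the scatter) therefore marks a weaker inhibitor, and its size rests on (the limit of > 1000 nM in this assay, at which 1 of the 2 values shown sits). Compound 3 `CCCn1c(=O)[nH]c2nc(-c3ccc(S(=O)(=O)N4CCN(c5ccccc5Br)CC4)cc3)[nH]c2c1=O` differs from compound 2 by 2-bromophenyl in place of 3-chlorophenyl on an amine nitrogen in a ring. Among the measured compounds shown here, only the step from compound 1 to compound 2 bears on this change, and it concerns a different exchange, so it gives little guidance; the swap between two such aryl groups is expected to stay close to the scatter, giving a step that the limit leaves unreadable from compound 2 to compound 3. Compound 3 is thus estimated at 1500 nM, within a range from 500 nM to 5000 nM, and may again show only a limit.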

Compound 3, inhibition constant: > 1000 nM
Compound 3 ended at the assay's limit; the forecaster's own chance of this, stated with the estimate: 60%; the middle value is on the limit's open side.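

In this assay compound 3 gives > 1000 nM, which is a limit of the test and not a number. The exchange of methyl for 2-bromophenyl on the amine nitrogen in the ring gives an at least 2.9-fold higher number from compound 1 to compound 3 (0.47 log units; beyond the scatter), so the weaker result at this position is no longer tied to 3-chlorophenyl alone, as a second halogen-bearing phenyl group behaves the same way. The step from the chlorine compound to the bromine compound cannot be read, so the two aryl groups cannot be ranked: the limit of > 1000 nM in this assay, at which 2 of the 3 values shown sit.

From the compounds shown here alone, it remains open whether the weakening belongs to aryl groups as such or to anything larger than methyl, which an ethyl chain or a benzyl group on that nitrogen could help to settle. The true values of compound 2 and compound 3 also stay hidden behind the limit.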